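A few compounds are considered here, and "the series" means these few. Any claim that something is new, unique, unknown or untested is made for them only; others in the source may bear on it.

Measured so far in a functional assay on NCI-H460 cells (Homo sapiens) for inhibition, read by sulforhodamine B assay, with a stated time of 48 h; on this read-out lower numbers stand for stronger inhibition of growth and higher numbers for weaker inhibition of growth:
Compound 1, `C=C(C)[C@@H]1CC=C(Cn2cc(COc3cccc(C4NC(=O)NC(C)=C4C(=O)OCC)c3)nn2)CC1`, gives a limit, > 100000 nM.
Compound 2, `C=C(C)[C@@H]1CC=C(Cn2cc(COc3cc(C4NC(=O)NC(C)=C4C(=O)OCC)ccc3OC)nn2)CC1`, gives a limit, > 100000 nM.
Compound 3, `C=C(C)[C@@H]1CC=C(Cn2cc(COc3cccc(C4NC(=O)NC5=C4C(=O)CC(C)(C)C5)c3)nn2)CC1`, gives 51600 nM.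

Within the data shown here, compound 3 thus carries the only number among the three; the other two values are limits. The change from compound 1 to compound 2 is methoxy in place of hydrogen on an aromatic carbon, and it gives a step that the two limits leave unreadable from compound 1 to compound 2; both values sit at the limit of > 100000 nM in this assay, at which 2 of the 3 values shown sit, so the size of that step cannot be read. The core of compound 3 differs from the core of compound 1, but that difference is not broken down here.

Compound 4, `C=C(C)[C@@H]1CC=C(Cn2cc(COc3cc(C4NC(=O)NC5=C4C(=O)CC(C)(C)C5)ccc3OC)nn2)CC1`, has not yet been measured. It differs from compound 3 by methoxy in place of hydrogen on an aromatic carbon, the same change as that made from compound 1 to compound 2, at a place described in the same words. The step from compound 3 to compound 4 is estimated at a 1.2-fold higher number from compound 3 to compound 4 (0.07 log units; within the scatter). This expectation rests on compound 3, whose value is 51600 nM, and on a step that the two limits leave unreadable from compound 1 to compound 2, which gives no readable size for the change, so no clear direction is taken. Compound 4 is expected to give 60000 nM in this assay, somewhere between 20000 nM and 150000 nM.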

Compound 4, concentration for total growth inhibition: > 100000 nM
Compound 4: only a limit was reported; the forecaster's own chance of this, stated with the estimate: 35%; middle value at least 1.6-fold (0.22 log units) away from the limit.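

In this assay, methoxy in place of hydrogen on an aromatic carbon gives an at least 1.9-fold higher number from compound 3 to compound 4 (0.28 log units; that floor lies within the scatter), and the floor of that step does not go beyond the usual scatter. On the core of compound 1 the same change joins two limits, so that step cannot be read and its size cannot be set against the step on the core of compound 3: the limit of > 100000 nM in this assay, at which 3 of the 4 values shown sit. The compounds therefore show no number lowered by methoxy on either core, but they do not show that the change has the same size on both, or that it truly weakens inhibition of growth on the core of compound 3.

Among these compounds, compound 3 remains the only compound with a number, so the effect of other groups at this place on its core stays open. Whether a hydroxy group, an amine or a carboxylic acid in place of the methoxy would give a readable number in this assay is not shown by these compounds.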